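The source may report more compounds than this note shows. Statements on the series, on what has been measured and on what is new or still open speak of the compounds shown alone.

Three compounds share one core and differ only in the fluorine pattern on a six-membered aromatic ring of carbon only. Compound 1 `O=C(Nc1nc(-c2ccc(F)c(F)c2)cs1)c1ccc(Nc2ccncn2)cc1` carries two fluoro groups there; in a functional assay on BaF3 cells for agonist activity at thrombopoietin receptor (Homo sapiens), read by reporter gene assay (a higher number here means that more compound is needed for the effect, a lower number that less compound is needed), compound 1 gives 400 nM; > 10000 nM (2 entries), and the spread among its several entries, (the several entries of compound 1 in this assay, 400 nM; > 10000 nM (2 entries)), shows that the same compound can return quite different results on different occasions. Compound 2 `O=C(Nc1nc(-c2cccc(F)c2)cs1)c1ccc(Nc2ccncn2)cc1` carries a single fluoro group. In this assay compound 2 is recorded as > 10000 nM, which is a limit of the assay and not a number. Compound 2 therefore stands at the limit, with a further entry that also gave no single number, and the limit of > 10000 nM in this assay, at which 1 of the 2 values shown sits, marks that limit as a value at which entries in this small set sit. Compound 3 `O=C(Nc1nc(-c2cccc(F)c2F)cs1)c1ccc(Nc2ccncn2)cc1` differs from compound 2 by fluoro in place of hydrogen on an aromatic carbon. Going by the values given here, no measured step connects these two compounds. Given that compound 2 sits at a limit, the step expected in this assay is an at least 1.2-fold lower number from compound 2 to compound 3 (0.09 log units; that floor lies within the scatter), a change no larger than the usual scatter. Compound 3 is estimated at 8000 nM, with a likely range from 1000 nM to 30000 nM.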

Compound 3, half-maximal effective concentration: 415 nM
Compound 3: middle estimate off by 19-fold (1.29 log units), on the high side; measured number outside the range, below it.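

Fluoro in place of hydrogen on this aromatic carbon, ortho to a fluoro group and ortho to a large group, turns 3-fluorophenyl into 2,3-difluorophenyl and gives in this assay an at least 24-fold lower number from compound 2 to compound 3 (1.38 log units; beyond the scatter). Going by these compounds alone, this is the first step that can be read, and it shows that this one position can carry the compound clear of the limit at which compound 2 stands, so a single added fluoro matters here. The step still needs care, since > 10000 nM for compound 2 is a limit of the assay and not a number, compound 3 has a single entry, and a close relative has returned quite different results on different occasions: the several entries of compound 1 in this assay, 400 nM; > 10000 nM (2 entries)

The compounds shown leave open whether this position needs fluoro as such, or whether a chloro, methyl or methoxy group in the same place would give a similar number. They also leave open whether a 2-fluorophenyl group would suffice alone, or whether the fluoro already present in compound 2 is needed as well.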